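A few compounds are considered here, and "the series" means these few. Any claim that something is new, unique, unknown or untested is made for them only; others in the source may bear on it.

Measured compounds in an assay on HEK293 cells for positive allosteric modulation of metabotropic glutamate receptor 2 (Rattus norvegicus), read by thallium flux, with a stated time of 2.5 min; a higher number here means a larger maximal response, a lower number a smaller maximal response:

Compound 1, `Cc1c(OCCCCOc2cccc(C(=O)O)c2)ccc(C(=O)CC(C)C)c1C`: 12.1%
Compound 2, `Cc1c(OCCCCOc2ccc(C(=O)O)c(Cl)c2)ccc(C(=O)CC(C)C)c1C`: 33.1%
Compound 3, `Cc1c(OCCCCOc2cccc(C(=O)O)c2)ccc(C(=O)CC2CCCC2)c1C`: 22.4%

Compound 2 differs from compound 1 by 4-carboxy-3-chlorophenyl in place of 3-carboxyphenyl on an oxygen on a saturated carbon; in this assay that change made a number 21 percentage points higher from compound 1 to compound 2 (beyond the scatter). Compound 3 differs from compound 1 at another site, by cyclopentyl in place of isopropyl on a saturated chain carbon bound to a carbonyl carbon, and this change made a number 10.3 percentage points higher from compound 1 to compound 3 (beyond the scatter). Going by the values given here, compound 2 and compound 3 have no directly compared step between them; their values simply show compound 2 at the higher number of the two.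

Compound 4, `Cc1c(OCCCCOc2ccc(C(=O)O)c(Cl)c2)ccc(C(=O)CC2CCCC2)c1C`, has not been measured. It differs from compound 3 by 4-carboxy-3-chlorophenyl in place of 3-carboxyphenyl on an oxygen on a saturated carbon, which is the same change already seen from compound 1 to compound 2, at a place described in the same words. The two cores differ by cyclopentyl in place of isopropyl on a saturated chain carbon bound to a carbonyl carbon. Among the compounds with values here, since the same change is being made on a core that starts at a higher value, compound 4 is expected to show a step of about a number 20.6 percentage points higher from compound 3 to compound 4 (beyond the scatter) in this assay, resting on the single earlier instance of this change, which made a number 21 percentage points higher from compound 1 to compound 2 (beyond the scatter). Compound 4 is therefore estimated at 43%, likely between 28% and 58%.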

Compound 4, largest response reached (reported as percent of maximum), in percent of the reference or control that the assay uses: 61.8%
Estimate against measurement, compound 4: 18.8 percentage points below; measured number above the stated range.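

In this assay, 4-carboxy-3-chlorophenyl in place of 3-carboxyphenyl gave a number 39.4 percentage points higher from compound 3 to compound 4 (beyond the scatter), so the change did not carry over at its earlier size to the core bearing cyclopentyl: the same change on two cores in this assay, a number 21 percentage points higher (beyond the scatter) from compound 1 to compound 2 and a number 39.4 percentage points higher (beyond the scatter) from compound 3 to compound 4, 18.4 percentage points apart, beyond the scatter of two such steps Read from the other site, cyclopentyl in place of isopropyl gave a number 28.7 percentage points higher from compound 2 to compound 4 (beyond the scatter), and this change too differed in size between its two cores: the same change on two cores in this assay, a number 10.3 percentage points higher (beyond the scatter) from compound 1 to compound 3 and a number 28.7 percentage points higher (beyond the scatter) from compound 2 to compound 4, 18.4 percentage points apart, beyond the scatter of two such steps The direction of each change held on both cores, but the two changes together gave more than their separate steps would add up to, and these four compounds alone do not show why this happens or whether it extends to other groups.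

As far as these compounds go, it remains open whether a fluorine in place of the chlorine on the carboxyphenyl group would pair with cyclopentyl in the same way. Equally open, from the compounds shown here alone, is whether a cyclohexyl in place of the cyclopentyl, or a longer chain in place of the one joining the two oxygens, would preserve this gain.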